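The compounds below may be only part of what the source reports. "The series", "measured", "known", "first", "only" and "open" are said of these compounds alone.

Measured so far in a functional assay on the whole organism (strain Sprague-Dawley) for inhibition, with Rattus norvegicus as the target; a higher number here means that more compound is needed for the effect, a lower number that less compound is needed:
Compound 1 `O=c1c(-c2nn[nH]n2)c[nH]c2c(F)cccc12` gives 10 mg/kg.
Compound 2 `Cc1cc(F)c2[nH]cc(-c3nn[nH]n3)c(=O)c2c1` gives only an assay limit, > 10 mg/kg.

Compound 1 therefore holds the only definite number shown; compound 2 sits at the limit of > 10 mg/kg in this assay, at which 1 of the 2 values shown sits. Going by the values given here, the one measured step, methyl in place of hydrogen on an aromatic carbon, is a number no lower from compound 1 to compound 2 (the limit leaves the size open). Compound 3 `COc1cccc2c(=O)c(-c3nn[nH]n3)c[nH]c12` differs from compound 1 by methoxy in place of fluoro on an aromatic carbon. Among the compounds with values here, no measured step swaps fluoro for methoxy, so there is no basis for expecting a change beyond the scatter in either direction. Compound 3 is thus expected to come out near 10 mg/kg, between 3 mg/kg and 30 mg/kg. The expected step is no change at the digits printed from compound 1 to compound 3 (within the scatter).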

Compound 3, minimum effective dose: 0.312 mg/kg
For compound 3 the middle estimate is 32-fold (1.51 log units) above the measured one, and the stated range ends above it.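

Putting methoxy in place of fluoro on this aromatic carbon gives a 32-fold lower number from compound 1 to compound 3 (1.51 log units; beyond the scatter) in this assay, so this one position on the shared core can strongly change the dose needed. Going by these compounds alone, compound 2 gave only a limit, so no earlier step had a readable size. Nothing in the data at hand explains why this swap has so large an effect.

On these data alone, it remains open whether the gain comes from adding methoxy or from losing fluoro, which a plain hydrogen here would help to separate. As far as these compounds go, whether ethoxy, hydroxyl or an amine would do as well also remains open.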